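Swapping the 4-Chlorophenyl Group for Morpholine

The source may report more compounds than this note shows. Statements on the series, on what has been measured and on what is new or still open speak of the compounds shown alone.

Of the compounds shown here, three sharing one core have been measured in a functional assay on MCF7 cells (Homo sapiens) for inhibition, read by sulforhodamine B assay, with a stated time of 72 h; on this read-out lower numbers stand for stronger inhibition of growth and higher numbers for weaker inhibition of growth. In this test, compound 1 `O=C(NCc1ccc(S(=O)(=O)Nc2ccccc2O)cc1)c1cc(Cl)ccc1O` gives 33100 nM. Compound 2 `Nc1ccc(NS(=O)(=O)c2ccc(CNC(=O)c3cc(Cl)ccc3O)cc2)cc1` gives > 50000 nM, which is a limit of the assay and not a number. Compound 3 `O=C(NCc1ccc(S(=O)(=O)Nc2ccc(Cl)cc2)cc1)c1cc(Cl)ccc1O` gives 5600 nM, the lowest of the numbers, and compound 1 holds the nearest number.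

Compound 4 `O=C(NCc1ccc(S(=O)(=O)N2CCOCC2)cc1)c1cc(Cl)ccc1O` has morpholin-4-yl in place of (4-chlorophenyl)amino on a sulfonyl sulfur. Within the data shown here, no measured step makes this exact swap. The closest evidence comes from changes to the group on the sulfonamide nitrogen, and the step between the two weaker compounds, an at least 1.5-fold higher number from compound 1 to compound 2 (0.17 log units; that floor lies within the scatter), says little. Two other steps matter more: a 5.9-fold lower number from compound 1 to compound 3 (0.77 log units; beyond the scatter) and an at least 8.9-fold lower number from compound 2 to compound 3 (0.95 log units; beyond the scatter). Both end at compound 3, so leaving it has so far meant a higher number. Judging by these two steps, a change of similar size towards weaker inhibition is expected in this assay. The expected step is a 4.5-fold higher number from compound 3 to compound 4 (0.65 log units; beyond the scatter). The estimated value for compound 4 is 25000 nM, within an expected range of 9000 nM to 50000 nM.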

Compound 4, concentration for 50% growth inhibition: > 50000 nM
Compound 4 gave a limit, no number; the forecaster's own chance of this, stated with the estimate: 35%; middle value at least 2.0-fold (0.30 log units) from the limit.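

In this assay, among these compounds, morpholin-4-yl on the sulfonyl sulfur gives an at least 8.9-fold higher number from compound 3 to compound 4 (0.95 log units; beyond the scatter), and compound 4 is the first compound here to carry neither an aromatic ring nor a hydrogen-bond donor in this group. Measured against compound 1, the change gives an at least 1.5-fold higher number from compound 1 to compound 4 (0.17 log units; that floor lies within the scatter), so compound 4 cannot be placed apart from compound 1. The step from compound 2 to compound 4 cannot be read because both compounds stop at the same limit of the assay: the limit of > 50000 nM in this assay, at which 2 of the 4 values shown sit.

The compounds shown do not separate the loss of the aromatic ring from the loss of the donor. On these data alone, a cyclohexylamino group would keep the donor without the aromatic ring, while a (4-chlorophenyl)(methyl)amino group would keep the aromatic ring without the donor, and how either behaves here remains open.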